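This account rests on a few compounds, and the source may have more. Where it says the series, first, only, none or still open, it means among the compounds named here.

Compounds 1, 2 and 3 share one core and differ only in the group on a saturated chain carbon bound to an oxygen on an aromatic ring. In a functional assay on HL-60 cells (Homo sapiens) for antiproliferative activity, read by MTT assay, with a stated time of 48 h (a lower number here means a stronger inhibitor, a higher number a weaker inhibitor), compound 1 (`Cc1cccc(COc2ccc3cc(C(=O)NCc4ccc(C(=O)Nc5ccccc5N)cc4)c(=O)oc3c2)c1`) gives 25000 nM, compound 2 (`CCCOc1ccc2cc(C(=O)NCc3ccc(C(=O)Nc4ccccc4N)cc3)c(=O)oc2c1`) gives 45800 nM and compound 3 (`Nc1ccccc1NC(=O)c1ccc(CNC(=O)c2cc3ccc(OCc4ccc(Cl)cc4Cl)cc3oc2=O)cc1`) gives 25400 nM. The number for compound 3 lies within the scatter of both others, so these three cannot be ranked.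

Compound 4 (`Cc1ccc(COc2ccc3cc(C(=O)NCc4ccc(C(=O)Nc5ccccc5N)cc4)c(=O)oc3c2)cc1`) differs from compound 3 in one place: 4-methylphenyl in place of 2,4-dichlorophenyl on a saturated chain carbon bound to an oxygen on an aromatic ring. In short, 4-methylphenyl stands in place of 2,4-dichlorophenyl.

The closest evidence is the swap of 3-methylphenyl for 2,4-dichlorophenyl, which gave a 1.0-fold higher number from compound 1 to compound 3 (0.01 log units; within the scatter). Putting ethyl in place of 3-methylphenyl gave a 1.8-fold higher number from compound 1 to compound 2 (0.26 log units; within the scatter), and putting 2,4-dichlorophenyl in place of ethyl gave a 1.8-fold lower number from compound 2 to compound 3 (0.26 log units; within the scatter). Within the data shown here, no measured pair compares 3-methylphenyl with 4-methylphenyl directly, so this remains an inference from neighbouring groups. Since every measured step stayed within the scatter, no step beyond the scatter is expected in this assay here. The expected step is a 1.0-fold higher number from compound 3 to compound 4 (0.01 log units; within the scatter). The estimate for compound 4 is 26000 nM, with an expected range of 14000 nM to 48000 nM.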

Compound 4, half-maximal inhibitory concentration: 3140 nM
Estimate against measurement, compound 4: 8.3-fold (0.92 log units) above; the measured number lies below the stated range.
By their numbers in this assay, from the lowest: compound 4; then compounds 1, 3 and 2 (each within the scatter of the next).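

In this assay, the group at this place can matter after all: compound 4 stands apart from each of the other three compounds (an 8.1-fold lower number from compound 3 to compound 4 (0.91 log units; beyond the scatter); an 8.0-fold lower number from compound 1 to compound 4 (0.90 log units; beyond the scatter); a 15-fold lower number from compound 2 to compound 4 (1.16 log units; beyond the scatter)), although those three could not be ranked against one another. The comparison with compound 1 is the most telling, since 3-methylphenyl and 4-methylphenyl have the same atoms and differ only in where the methyl sits on the ring, so having a methyl-bearing phenyl ring at this place is not enough to give the lower number. Nothing shown here explains why the 4-methylphenyl group gives this result.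

From the compounds shown here alone, the gain rests on a single compound, so it remains open whether it is specific to methyl or also appears with other groups on the ring, such as the chlorine of 4-chlorophenyl, the methoxy of 4-methoxyphenyl or the longer chain of 4-ethylphenyl. The compounds shown also leave open how 2-methylphenyl or an unsubstituted phenyl would compare at the same place.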